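The source may report more compounds than this note shows. Statements on the series, on what has been measured and on what is new or still open speak of the compounds shown alone.

Compounds measured so far in this study:

compound 1, `O=C1/C(=C/c2ccc(O)cc2)CCC/C1=C\c1ccc([N+](=O)[O-])cc1`: 4400 nM
compound 2, `O=C1/C(=C/c2ccc(O)cc2)Cc2ccccc2/C1=C\c1ccc([N+](=O)[O-])cc1`: 2500 nM
compound 3, `COc1cc(/C=C2/C(=O)/C(=C/c3ccc([N+](=O)[O-])cc3)c3ccccc32)cc(OC)c1OC`: 318000 nM

In a functional assay on HL-60 cells (Homo sapiens) for cytotoxicity (on this read-out higher numbers stand for lower toxicity in this test and lower numbers for higher toxicity in this test), compound 1 gives 4400 nM, the second highest of these three numbers. The number for compound 2 sits so close to it that the two cannot be told apart within the usual scatter. Compound 3, by contrast, gives a far higher number, a gap well beyond the scatter, so compound 3 is clearly the less toxic of that pair.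

Compound 4, `O=C1/C(=C/c2ccc(Cl)cc2)CCC/C1=C\c1ccc([N+](=O)[O-])cc1`, has not yet been measured. It differs from compound 1 in one place: chloro in place of hydroxy on an aromatic carbon. Going by the values given here, no measured pair shows this change, so its effect is unknown here. A small step is expected, a 1.1-fold lower number from compound 1 to compound 4 (0.04 log units; within the scatter), most likely within the scatter. Compound 4 is therefore estimated at 4000 nM, with a range from 1500 nM to 12000 nM.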

Compound 4, half-maximal cytotoxic concentration: 4100 nM
Beside the measured number, compound 4's estimate is 1.0-fold (0.01 log units) below it, and the stated range covers the measured number.
By their numbers in this assay, from the lowest: compounds 2, 4 and 1 (each within the scatter of the next); then compound 3.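

Putting chloro in place of hydroxy on this aromatic carbon gives a 1.1-fold lower number from compound 1 to compound 4 (0.03 log units; within the scatter) in this assay. The earlier compounds shown here held no such pair, and this one shows that the read-out does not separate 4-hydroxyphenyl from 4-chlorophenyl on the core of compound 1, even though only hydroxy counts a hydrogen-bond donor. Nothing available explains why the two read alike.

Going by these compounds, whether an amine or a carboxylic acid at this place would also stay within the scatter remains open. So does whether the same swap on the core of compound 2 would read alike.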